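The compounds below may be only part of what the source reports. "The series", "measured", "known", "first", "only" and "open" are said of these compounds alone.

Measured so far:
compound 1 `O=C(CCCc1nc2ccccc2c(=O)[nH]1)N/N=C/c1cc(O)c(O)c(O)c1`: 183000000 nM
compound 2 `COc1cc(/C=N/NC(=O)CCCc2nc3ccccc3c(=O)[nH]2)cc(OC)c1O`: 524000000 nM

In a functional assay on cells (Erythrocyte, Homo sapiens) for inhibition, read by spectrophotometry and hemolysis, with a stated time of 10 min (a higher number here means a weaker inhibitor, a lower number a stronger inhibitor), compound 2 gives 524000000 nM as the higher of the two numbers, which makes it the weaker inhibitor of the pair. Compound 3 `COc1cc(/C=N/NC(=O)CCCc2nc3ccccc3c(=O)[nH]2)cc(O)c1O` differs from compound 2 in one place, with hydrogen in place of methyl on an oxygen on an aromatic ring. Among the compounds with values here, no measured step shows this change, so the only guide is the spread of the two values, with compound 1 at 183000000 nM as the lower one. The estimated step is a 1.7-fold lower number from compound 2 to compound 3 (0.24 log units; within the scatter) and would be a modest move toward a lower number. For compound 3 the estimated value is 300000000 nM within an expected range from 130000000 nM to 700000000 nM in this measurement.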

Compound 3, half-maximal inhibitory concentration in the Erythrocyte assay: 277000000 nM
Compound 3: middle estimate off by 1.1-fold (0.03 log units), on the high side; measured number inside the range.
By their numbers in the Erythrocyte assay, from the lowest: compounds 1, 3 and 2 (each within the scatter of the next, the first and the last beyond it).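

In the Erythrocyte assay, methoxy to hydroxy at this position gives a 1.9-fold lower number from compound 2 to compound 3 (0.28 log units; within the scatter), and adding a methyl on an oxygen of compound 1 gives a 1.5-fold higher number from compound 1 to compound 3 (0.18 log units; within the scatter), so neither single change separates these compounds there. With both members of the pair measured in a physicochemical assay, read by spectrophotometry, with a stated time of 6 min (a lower number here means a stronger inhibitor, a higher number a weaker inhibitor), compound 2 gives 135000000 nM and compound 3 gives 50000000 nM so the same methoxy to hydroxy change is also seen to stand out from the scatter: the measured half-maximal inhibitory concentration of compound 2, 135000000 nM, and of compound 3, 50000000 nM, a 2.7-fold lower number (0.43 log units; beyond the scatter)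

The compounds shown leave open whether an ethoxy group or an amine in this place would keep or shift these numbers. They also leave open what a longer chain to the shared core would do.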